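Swapping a Cyclohexyl Ring for an Oxan-4-yl Ring

A few compounds are considered here, and "the series" means these few. Any claim that something is new, unique, unknown or untested is made for them only; others in the source may bear on it.

Of the compounds shown here, three built on one shared core have been tested in a functional assay on cells for antagonist activity at C-X-C chemokine receptor type 4 (Homo sapiens), read by fluorescence and calcium flux, with stated times of 25 min and 90 s; on this read-out higher numbers stand for weaker inhibition and lower numbers for stronger inhibition. Compound 1 `c1cncc(CNCCCCN(C[C@H]2Cc3ccccc3CN2)[C@H]2CCCc3cccnc32)c1` gives 15.3 nM in this assay. Compound 2 `c1ccc(CNCCCCN(C[C@H]2Cc3ccccc3CN2)[C@H]2CCCc3cccnc32)cc1` gives 20.1 nM. Compound 3 `c1ccc2c(c1)CN[C@@H](CN(CCCCNCC1CCCCC1)[C@H]1CCCc3cccnc31)C2` gives 158 nM, the highest number of the three and so the weakest inhibitor among them. The move from pyridin-3-yl to phenyl is small: a 1.3-fold higher number from compound 1 to compound 2 (0.12 log units; within the scatter). Replacing the aromatic ring with a saturated one costs more: a 10-fold higher number from compound 1 to compound 3 (1.01 log units; beyond the scatter) and a 7.9-fold higher number from compound 2 to compound 3 (0.90 log units; beyond the scatter).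

Compound 4 `c1ccc2c(c1)CN[C@@H](CN(CCCCNCC1CCOCC1)[C@H]1CCCc3cccnc31)C2` has not yet been measured. It differs from compound 3 in one place: oxan-4-yl in place of cyclohexyl on a saturated chain carbon bound to an amine nitrogen. Among the measured compounds shown here, no measured step makes exactly this change. The nearest comparison is the exchange, on the aromatic side, of a ring of carbon only for a ring holding one hetero atom, and that step stayed within the scatter: a 1.3-fold higher number from compound 1 to compound 2 (0.12 log units; within the scatter). The steps from an aromatic to a saturated ring bear less directly on the question, as compound 3 and compound 4 both carry a saturated ring. A step for compound 4 that stays within the scatter is therefore expected: a 1.2-fold lower number from compound 3 to compound 4 (0.08 log units; within the scatter). Compound 4 is estimated at 130 nM, with a range from 45 nM to 400 nM.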

Compound 4, half-maximal inhibitory concentration: 52.9 nM
Estimate against measurement, compound 4: 2.5-fold (0.39 log units) above; low and high end bracket the measured number.
By their numbers in this assay, from the lowest: compounds 1 and 2 (each within the scatter of the next); then compound 4; then compound 3.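

In this assay, among the compounds shown here, this position responds to a change inside a saturated ring: putting one oxygen into the ring gives a step beyond the scatter (a 3.0-fold lower number from compound 3 to compound 4 (0.48 log units; beyond the scatter)), whereas the one ring exchange seen earlier with a hetero atom, on the aromatic side, stayed within it (a 1.3-fold higher number from compound 1 to compound 2 (0.12 log units; within the scatter)). The oxan-4-yl ring recovers only part of what the saturated cyclohexyl ring lost, as compound 4 still falls short of both aromatic compounds (a 2.6-fold higher number from compound 2 to compound 4 (0.42 log units; beyond the scatter); a 3.5-fold higher number from compound 1 to compound 4 (0.54 log units; beyond the scatter)), so a saturated ring at this position need not cost the full amount seen with compound 3. Nothing available here accounts for the gain from the oxygen.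

Going by these compounds, it remains open whether another hetero atom in the same saturated ring, such as the amine nitrogen of a piperidin-4-yl group, or a hydroxyl group on the cyclohexyl ring, would give a similar step. On these data alone, it is also open whether the oxan-3-yl ring, with its oxygen placed differently, or a longer chain carrying the oxan-4-yl ring would keep the gain.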